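The source may hold more compounds than are shown below. What is called first, only, known or untested is meant among the compounds shown, and "the series" means these compounds.

Compound 1, `COc1cc2ncnc(NNC(=S)NC(=O)c3ccc(F)cc3)c2cc1OC`, is the starting point. In a functional assay on KB cells (Homo sapiens) for cytotoxicity, read by MTT assay, with a stated time of 72 h (on this read-out higher numbers stand for weaker inhibition and lower numbers for stronger inhibition), compound 1 gives 4530 nM. Among the two plain numbers shown it is the highest, though compound 3, `O=C(NC(=S)NNc1ncnc2ccccc12)c1ccc(Cl)cc1`, sits close by with 3940 nM, a gap that stays within the scatter. Compound 2, `COc1ccccc1C(=O)NC(=S)NNc1ncnc2ccccc12`, gives only a limit of the assay, > 50000 nM. This is the limit at which (the limit of > 50000 nM in this assay, at which 1 of the 3 values shown sits). Going by the values given here, the one step measured between neighbours is an at least 12-fold lower number from compound 2 to compound 3 (1.10 log units; beyond the scatter), where 4-chlorophenyl replaces 2-methoxyphenyl on a carbonyl carbon.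

Compound 4 is `COc1cc2ncnc(NNC(=S)NC(=O)c3ccc(C)cc3)c2cc1OC`. The change from compound 1 is methyl in place of fluoro on an aromatic carbon. Among the compounds with values here, no measured step swaps one small group for another at this aromatic carbon, so the chlorine-for-methoxy step gives no direct guide; it shows only that the carbonyl-bound ring tolerates a substituent para to a large group. A step within the scatter is therefore expected from compound 1 to compound 4, namely a 1.1-fold lower number from compound 1 to compound 4 (0.03 log units; within the scatter). Compound 4 is estimated at 4200 nM, between 1500 nM and 12000 nM.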

Compound 4, half-maximal inhibitory concentration: 24200 nM
The estimate for compound 4 lay 5.8-fold (0.76 log units) below the measured number; the measured number lies above the stated range.
By their numbers in this assay, from the lowest: compounds 3 and 1 (each within the scatter of the next); then compound 4. At a limit, above all of these: compound 2.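

The a 5.3-fold higher number from compound 1 to compound 4 (0.73 log units; beyond the scatter) in this assay shows that this position responds even when one heavy atom replaces another, with the group staying in the same place on the ring. The earlier step from compound 2 to compound 3 could not show this, since it exchanged two different groups that also sit at different places on the ring. Nothing shown here explains why methyl and fluoro differ at this aromatic carbon, and the only available supporting information concerns an assay limit that has no bearing on this step.

As far as these compounds go, what an amine, a hydroxyl or a carboxylic acid would give at this same position remains open. From the compounds shown here alone, it is also open whether the swap from 4-fluorophenyl to 4-methylphenyl would produce a similar step on the core of compound 3.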